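This account rests on a few compounds, and the source may have more. Where it says the series, first, only, none or still open, it means among the compounds named here.

Compound 1 `CC(=O)N(Cc1ccc(OCCF)cc1)c1cc(C)cc(C)c1`, compound 2 `CCN(CC)C(=O)CN(Cc1ccccc1)c1cc(C)cc(C)c1` and compound 3 `CCN(CC)C(=O)CN(Cc1ccc(OC)cc1)c1cc(C)cc(C)c1` share a core and differ in the amide and in the benzyl substituent. In an assay on membranes from HEK293 cells for displacement of a labelled ligand from Translocator protein (Homo sapiens), read by scintillation counting, with a stated time of 90 min (on this read-out lower numbers stand for stronger inhibition and higher numbers for weaker inhibition), compound 1 gives 275 nM, compound 2 gives 1010 nM and compound 3 gives 1200 nM. Compound 3 and compound 2 sit within the scatter of each other, the step from compound 2 to compound 3 being a 1.2-fold higher number from compound 2 to compound 3 (0.07 log units; within the scatter), whereas the gap from compound 3 to compound 1 lies beyond the scatter, compound 1 giving the smaller number of the pair. Compound 4 `CCN(CC)C(=O)CN(Cc1ccc(OCCF)cc1)c1cc(C)cc(C)c1` keeps the amide of compound 3 and changes the benzyl substituent: fluoromethyl in place of hydrogen on a saturated chain carbon bound to an oxygen on an aromatic ring. For the measured compounds named here, no measured step carries exactly this change; compound 1 holds the 2-fluoroethoxy group but also a different amide, so its value is only a loose hint. Going by the values given here, the one nearby step, a substituent change on the same aromatic carbon, was within the scatter. For compound 4 in this assay a step of a 1.3-fold lower number from compound 3 to compound 4 (0.12 log units; within the scatter) is therefore expected, small and not clearly beyond the scatter. Compound 4 is estimated at 900 nM, within 400 nM to 2000 nM.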

Compound 4, inhibition constant: 1290 nM
Beside the measured number, compound 4's estimate is 1.4-fold (0.16 log units) below it, and the stated range covers the measured number.
By their numbers in this assay, from the lowest: compound 1; then compounds 2, 3 and 4 (each within the scatter of the next).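

In this assay, lengthening methoxy to 2-fluoroethoxy gives a 1.1-fold higher number from compound 3 to compound 4 (0.03 log units; within the scatter) and replacing hydrogen on the aromatic carbon with 2-fluoroethoxy gives a 1.3-fold higher number from compound 2 to compound 4 (0.11 log units; within the scatter), so hydrogen, methoxy and 2-fluoroethoxy are not told apart at this position among compound 2, compound 3 and compound 4. For the compounds shown here, with 2-fluoroethoxy held fixed, (diethylcarbamoyl)methyl in place of acetyl on the nitrogen gives a 4.7-fold higher number from compound 1 to compound 4 (0.67 log units; beyond the scatter), the only new step beyond the scatter, though a modest one. Nothing available bears on the reason for these results.

On these data alone, a longer chain such as 3-fluoropropoxy, or an amine at the end of the chain, remains open at this position. Also open, as far as these compounds go, is whether the benzyl substituent has a larger effect with the acetyl group of compound 1 on the nitrogen.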